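Arylamino in place of alkylamino on the pyridine amide core

The compounds below may be only part of what the source reports. "The series", "measured", "known", "first", "only" and "open" are said of these compounds alone.

Compound 1 `C=CCOc1ccc(C(=O)Nc2cccc(CC)n2)cc1` gives 20500 nM in an in vitro assay on HEK-tsA201 cells for antagonist activity at Neuronal acetylcholine receptor; alpha4/beta2 (Homo sapiens), read by fluorescence and calcium flux; on this read-out higher numbers stand for weaker inhibition and lower numbers for stronger inhibition. Compound 2 `CCCOc1ccc(C(=O)Nc2cccc(Cl)n2)cc1` reports only a limit, > 100000 nM, in this assay. Compound 3 `CCCNc1cccc(NC(=O)c2ccc(OCCC)cc2)n1` gives 15400 nM in this assay; compound 3 and compound 1 sit within the scatter of each other. Within the data shown here, the one measured step, an at least 6.4-fold lower number from compound 2 to compound 3 (0.81 log units; beyond the scatter), starts from the limit of > 100000 nM in this assay, at which 1 of the 3 values shown sits, and so is open-ended. Compound 4 `CCCOc1ccc(C(=O)Nc2cccc(Nc3ccccc3F)n2)cc1` differs from compound 3 by 2-fluorophenyl in place of propyl on a nitrogen on an aromatic ring. Among the measured compounds shown here, no measured step swaps one substituent for another on that nitrogen, so the only step gives no direction for this change. For compound 4 a change of a 1.3-fold lower number from compound 3 to compound 4 (0.11 log units; within the scatter) is expected, within the scatter. Compound 4 is estimated at 12000 nM, spanning 3000 nM to 50000 nM in this assay.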

Compound 4, half-maximal inhibitory concentration: > 100000 nM
Compound 4 ended at the assay's limit; the forecaster's own chance of this, stated with the estimate: 10%; middle value at least 8.3-fold (0.92 log units) away from the limit.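

Among these compounds, on the nitrogen on an aromatic ring, replacing propyl with 2-fluorophenyl gives an at least 6.4-fold higher number from compound 3 to compound 4 (0.81 log units; beyond the scatter) in this assay, the first swap of one substituent for another at this place. The lower number seen with propylamino in place of chloro therefore does not extend to (2-fluorophenyl)amino. Compound 4 gives a limit, not a number, and the step from compound 2 to compound 4 cannot be read: the limit of > 100000 nM in this assay, at which 2 of the 4 values shown sit.

As far as these compounds go, whether a longer chain such as pentyl or a benzyl group on that nitrogen would hold the number seen with propyl stays open. So does whether unsubstituted phenyl would behave like 2-fluorophenyl.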